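Working notes: compound 3 after compound 2

This account rests on a few compounds, and the source may have more. Where it says the series, first, only, none or still open, it means among the compounds named here.

Measured compounds:
compound 1 `COC(=O)c1cc(O)ccc1OC(=O)COc1cc(O)c2c(=O)cc(-c3ccccc3)oc2c1` — 263000 nM
compound 2 `COC(=O)c1cc(Br)ccc1OC(=O)COc1cc(O)c2c(=O)cc(-c3ccccc3)oc2c1` — > 450000 nM

In an ADME assay on cells (T-cell, Mus musculus, strain BALB/c) for cytotoxicity, read by MTT assay, with a stated time of 48 h (a lower number here means that less compound is tolerated, a higher number that more compound is tolerated), compound 1 gives 263000 nM. For compound 2 the assay reports only a limit, > 450000 nM, so compound 2 stands at that limit of > 450000 nM in this assay, at which 1 of the 2 values shown sits, rather than at a number. Within the data shown here, the single measured step, an at least 1.7-fold higher number from compound 1 to compound 2 (0.23 log units; that floor lies within the scatter), has a floor within the scatter. Compound 3 `COC(=O)c1cc(C)ccc1OC(=O)COc1cc(O)c2c(=O)cc(-c3ccccc3)oc2c1` differs from compound 2 by methyl in place of bromo on an aromatic carbon. Among the measured compounds shown here, no measured step covers this change, so a step of an at least 1.1-fold lower number from compound 2 to compound 3 (0.05 log units; that floor lies within the scatter) is expected that stays within the scatter. Compound 3 is estimated at 400000 nM, between 200000 nM and 900000 nM.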

Compound 3, half-maximal cytotoxic concentration: 306000 nM
The estimate for compound 3 lay 1.3-fold (0.12 log units) above the measured number; low and high end bracket the measured number.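

With methyl on this aromatic carbon, para to a large group, hydroxy to methyl gives a 1.2-fold higher number from compound 1 to compound 3 (0.07 log units; within the scatter) in this assay, so this exchange does not separate the two compounds. Bromo to methyl gives an at least 1.4-fold lower number from compound 2 to compound 3 (0.16 log units; that floor lies within the scatter), which is only a floor. Compound 2 stands at a limit rather than a number: the limit of > 450000 nM in this assay, at which 1 of the 3 values shown sits.

As far as these compounds go, how far bromo really lies from methyl stays open, since a floor within the scatter settles neither size nor direction. Also open, from the compounds shown here alone, is whether an amine or a carboxylic acid at this position would move the number beyond the scatter.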